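The source may report more compounds than this note shows. Statements on the series, on what has been measured and on what is new or still open speak of the compounds shown alone.

Measured so far:
compound 1 `CCCCCCC#Cc1c(CCCCCC)oc2nc(=O)n(Cc3cn(-c4ccc(F)cc4)nn3)cc12` gives > 100000 nM in a functional assay on CFPAC-1 cells (Homo sapiens) for antiproliferative activity, read by MTT assay, with a stated time of 72 h; a higher number here means a weaker inhibitor, a lower number a stronger inhibitor;
compound 2 `O=c1c(I)cn(Cc2cn(Cc3ccccc3)nn2)c(=O)n1Cc1cn(Cc2ccccc2)nn1` gives > 100000 nM in this assay.

Compound 1 stands at the limit of > 100000 nM in this assay, at which 2 of the 2 values shown sit; this is a limit of the assay, not a number. The value of compound 2 is likewise a limit. Among the compounds with values here, no step between measured compounds can be drawn from two limits.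

Compound 3 `CCCCCCC#Cc1c(CCCCCC)oc2nc(=O)n(Cc3cn(Cc4ccccc4)nn3)cc12` is not yet measured. It differs from compound 1 by benzyl in place of 4-fluorophenyl on an aromatic nitrogen. Within the data shown here, with no measured step to lean on, the expected step from compound 1 to compound 3, a number no higher from compound 1 to compound 3 (the limit leaves the size open), is none beyond the scatter. In this assay compound 3 is therefore expected near 100000 nM, within 30000 nM to 300000 nM, most probably reported again only as a limit.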

Compound 3, half-maximal inhibitory concentration: 27300 nM
Compound 3: middle estimate off by 3.7-fold (0.56 log units), on the high side; measured number outside the range, below it.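

In this assay, benzyl in place of 4-fluorophenyl on this aromatic nitrogen gives an at least 3.6-fold lower number from compound 1 to compound 3 (0.56 log units; beyond the scatter). This shows that the position can respond to a single change on the shared core, which two limits alone could not show. The true size of the step remains unknown, because the value of compound 1 is a limit: the limit of > 100000 nM in this assay, at which 2 of the 3 values shown sit.

Open, on these data alone, is whether the shift follows from losing the fluorine or from the added carbon of benzyl; unsubstituted phenyl and 4-fluorobenzyl would separate the two. Also open, as far as these compounds go, is how a longer chain, such as 2-phenylethyl, or an amine on the benzyl ring would read here.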